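Propyl to butyl on the shared core

The source may report more compounds than this note shows. Statements on the series, on what has been measured and on what is new or still open speak of the compounds shown alone.

Measured in a functional assay on the whole organism with Mus musculus as the target; on this read-out lower numbers stand for an effect already at smaller amounts and higher numbers for an effect only at larger amounts of compound:
- Compound 1 `c1ccn(Nc2ccncc2)c1`: > 20 mg/kg (a limit)
- Compound 2 `CCCN(c1ccncc1)n1cccc1`: > 20 mg/kg (a limit)

Compound 2 stands at > 20 mg/kg, which is a limit and not a number. Both measured compounds share (the limit of > 20 mg/kg in this assay, at which 2 of the 2 values shown sit), so the series has no numerical value yet.

Compound 3 `CCCCN(c1ccncc1)n1cccc1` differs from compound 2 by a single change: methyl in place of hydrogen on a saturated chain carbon, three bonds along the chain from a nitrogen on an aromatic ring. Cut one bond further out, the same difference reads propyl to butyl.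

Within the data shown here, only one measured step bears on this change, and it is a step that the two limits leave unreadable from compound 1 to compound 2. It introduced the propyl group that is now extended, but it gives no size or direction to carry forward. No step beyond the scatter can therefore be expected in this assay, in either direction. The expected step is a step that the limit leaves unreadable from compound 2 to compound 3.

Compound 2 gives only a limit as a starting point, so the expectation stays wide, and a further limit is the more likely report. The estimate for compound 3 is 30 mg/kg, with an expected range from 12 mg/kg to 80 mg/kg.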

Compound 3, dose for half-maximal effect: > 20 mg/kg
Compound 3 gave a limit, no number; the forecaster's own chance of this, stated with the estimate: 75%; the middle value lies beyond the limit too.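

No new step can be read among compound 1, compound 2 and compound 3 in this assay, because all three report only a limit and no number: the limit of > 20 mg/kg in this assay, at which 3 of the 3 values shown sit.

The compounds shown leave open whether hydrogen, propyl or butyl on this nitrogen differ at all in this assay, and in which direction.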